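Replacing a phenol with dimethoxyphenyl in a cytotoxicity series

The source may report more compounds than this note shows. Statements on the series, on what has been measured and on what is new or still open speak of the compounds shown alone.

Compound 3 `CN(C)CCn1cnnc1-c1cc(Oc2ccc(NC(=O)N/N=C/c3ccc(O)cc3)cc2F)ccn1` has no single number to stand on: in an ADME assay on WI-38 cells (Homo sapiens) for cytotoxicity, read by MTT assay, with a stated time of 72 h (on this read-out lower numbers stand for stronger inhibition and higher numbers for weaker inhibition), compound 3 is recorded as "not determined" (no result reported). Its relatives do have numbers. For the measured compounds named here, compound 1 `CN(C)CCn1cnnc1-c1cc(Oc2ccc(NC(=O)N/N=C/c3ccc(Cl)cc3)cc2F)ccn1` gives 1870 nM in this assay, and compound 2 `CN(C)CCn1cnnc1-c1cc(Oc2ccc(NC(=O)N/N=C/c3cccc(Cl)c3Cl)cc2F)ccn1` gives 6130 nM; the only measured step, a 3.3-fold higher number from compound 1 to compound 2 (0.52 log units; beyond the scatter), is modest and shows that swapping substituents on this ring moves the read-out within a narrow band. Compound 4 `COc1ccc(/C=N/NC(=O)Nc2ccc(Oc3ccnc(-c4nncn4CCN(C)C)c3)c(F)c2)c(OC)c1` carries the change (2,4-dimethoxyphenyl in place of 4-hydroxyphenyl on a carbon with a double bond to nitrogen). Going by the values given here, no measured step touches a hydroxyl or methoxy group, so the expectation for compound 4 rests on the two measured values alone, without a step of its own. Compound 4 is therefore expected to fall near 3200 nM, within a range of 1000 nM to 10000 nM.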

Compound 4, half-maximal inhibitory concentration: 6630 nM
Compound 4: middle estimate off by 2.1-fold (0.32 log units), on the low side; the range from low to high includes it.
By their numbers in this assay, from the lowest: compound 1; then compounds 2 and 4 (each within the scatter of the next).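

In this assay the 2,4-dimethoxyphenyl group cannot be told apart from the 2,3-dichlorophenyl group (a 1.1-fold higher number from compound 2 to compound 4 (0.03 log units; within the scatter)), so two quite different ring groups on this carbon give the same read-out within the scatter. Against the 4-chlorophenyl group the gap is real but still modest (a 3.5-fold higher number from compound 1 to compound 4 (0.55 log units; beyond the scatter)), and of these three compounds only compound 1, with its single chlorine, stands apart. Nothing available explains why this is so. From the compounds shown here alone, how the 4-hydroxyphenyl group of compound 3 compares in this place stays open, as does whether a ring carrying an amine or a carboxylic acid would leave this narrow band.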